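The compounds below may be only part of what the source reports. "The series", "measured", "known", "first", "only" and "open" are said of these compounds alone.

For the measured compounds named here, in a functional assay on U-373MG ATCC cells (Homo sapiens) for inhibition, read by MTT assay, with a stated time of 72 h (a higher number here means a weaker inhibitor, a lower number a stronger inhibitor), compound 2 `CC(C)NC(=O)NC1CC(C)(C)Oc2ccc(Cl)cc21` sits at 62000 nM and holds the higher of the two numbers so far. Compound 1 `CC1(C)CC(NC(=O)Nc2ccc(Cl)cc2)c2cc(F)ccc2O1` stands at 24000 nM in the same read-out. The gap between these two numbers lies beyond the usual scatter. Compound 3 `CC1(C)CC(NC(=O)Nc2ccc(Cl)cc2)c2cc(Cl)ccc2O1` is reached from compound 2 through one change: 4-chlorophenyl in place of isopropyl on an amide-type nitrogen is the counted difference, 4-chlorophenyl in place of isopropyl on an amide-type nitrogen. Going by the values given here, no step between measured compounds is available to size this change directly. Among the compounds with values here, the only guide is compound 1, which also bears a 4-chlorophenyl on an amide-type nitrogen and gives 24000 nM as its number, lower than that of compound 2. A moderate step toward a lower number is therefore expected in this assay, roughly the size of the gap already seen, and it may only just clear the scatter. The expected change is a 2.8-fold lower number from compound 2 to compound 3 (0.45 log units; beyond the scatter) in this estimate. For compound 3 the estimated half-maximal inhibitory concentration is 22000 nM with an expected range between 9000 nM and 50000 nM on this reckoning.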

Compound 3, half-maximal inhibitory concentration: 19000 nM
The estimate for compound 3 lay 1.2-fold (0.06 log units) above the measured number; the range from low to high includes it.
By their numbers in this assay, from the lowest: compounds 3 and 1 (each within the scatter of the next); then compound 2.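

In this assay the change on the amide-type nitrogen can now be sized directly: 4-chlorophenyl in place of isopropyl gives a 3.3-fold lower number from compound 2 to compound 3 (0.51 log units; beyond the scatter), a modest step that lies beyond the scatter. The second change, chloro in place of fluoro on an aromatic carbon, gives a 1.3-fold lower number from compound 1 to compound 3 (0.10 log units; within the scatter), so this pair shows no readable difference between the two halogens at that position. Nothing measured here explains either step.

For the compounds shown here, the nitrogen has been seen with only two groups, isopropyl and 4-chlorophenyl, so it remains open whether the gain belongs to the aromatic ring itself or to its chlorine, a question that unsubstituted phenyl or a cyclohexyl group would address. On the aromatic carbon, only the two halogens are shown, which leaves open whether a hydrogen, a methoxy group, a nitrile or an amine there would separate from them by more than the scatter.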